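Saturating the long chain of compound 1

The compounds below may be only part of what the source reports. "The series", "measured", "known", "first", "only" and "open" are said of these compounds alone.

Compound 1 (`CCCCCCCC/C=C\CCCCCCCCOc1cc(O)cc(O)c1C(C)=O`) gives 31000 nM in a functional assay on HT-29 cells (Homo sapiens) for cytotoxicity, read by XTT assay, with a stated time of 72 h (a higher number here means a weaker inhibitor, a lower number a stronger inhibitor), and compound 2 (`CC(C)=CCC/C=C(\C)Cc1c(O)cc(O)c2c(=O)c(OC/C=C(\C)CCC=C(C)C)c(-c3ccc(O)cc3)oc12`) gives 30000 nM at the same level, within the scatter. decyl in place of dec-1-en-1-yl on a saturated chain carbon, eight bonds along the chain from an oxygen on an aromatic ring sets compound 3 (`CCCCCCCCCCCCCCCCCCOc1cc(O)cc(O)c1C(C)=O`) apart from compound 1, with decyl in place of dec-1-en-1-yl on a saturated chain carbon, eight bonds along the chain from an oxygen on an aromatic ring. Going by the values given here, no measured step covers this change, so the expectation rests on compound 1 at 31000 nM alone. The expected step of a 1.3-fold higher number from compound 1 to compound 3 (0.11 log units; within the scatter) is a slight weakening that stays within the scatter. Compound 3 is estimated at 40000 nM (expected range 15000 nM to 100000 nM).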

Compound 3, half-maximal inhibitory concentration: > 100000 nM
Compound 3: no number, only a limit; the forecaster's own chance of this, stated with the estimate: 25%; at least 2.5-fold (0.39 log units) between middle value and limit.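

In this assay compound 3 carries a limit, not a number: > 100000 nM. Decyl in place of dec-1-en-1-yl gives an at least 3.2-fold higher number from compound 1 to compound 3 (0.50 log units; beyond the scatter), so at this position, on a saturated chain carbon, eight bonds along the chain from an oxygen on an aromatic ring, losing the one double bond alone moves the read-out beyond the scatter. The size of this step is only a lower bound: the limit of > 100000 nM in this assay, at which 1 of the 3 values shown sits.

From the compounds shown here alone, the true size of the step remains open. Also open, going by these compounds, is whether a shorter saturated chain or an amine in place of decyl would return a measurable number.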